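The compounds below may be only part of what the source reports. "The series", "measured", "known", "first", "only" and "open" are said of these compounds alone.

Working notes on the series.

Compound 1 `COc1ccc(-c2cc(COc3ccccc3-c3nc4ccccc4s3)on2)cc1` carries a methoxy group on its outer ring, while compound 2 `c1ccc(-n2cc(COc3ccccc3-c3nc4ccccc4s3)nn2)cc1` replaces the whole five-membered linking ring and its substituent pattern. In a functional assay on COLO 205 cells (Homo sapiens) for cytotoxicity, read by MTT assay, with a stated time of 24 h (on this read-out higher numbers stand for weaker inhibition and lower numbers for stronger inhibition), compound 1 gives 20700 nM, and compound 2 gives 16600 nM. Compound 1 has the highest of the two numbers recorded, but the gap to compound 2 is within the usual scatter, so the two cannot be told apart on these data.

Compound 3 `Clc1ccc(-c2cc(COc3ccccc3-c3nc4ccccc4s3)on2)cc1` has not yet been tested. Against compound 1 the change is chloro in place of methoxy on an aromatic carbon. For the measured compounds named here, no step between measured compounds that differ in one place exists, so this change has no measured precedent here.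

On the two values in hand, the expectation for compound 3 is a step that stays within the scatter, if anything toward a somewhat lower number, giving a 1.5-fold lower number from compound 1 to compound 3 (0.17 log units; within the scatter). The estimated value for compound 3 in this assay is 14000 nM, with a range from 6000 nM to 35000 nM.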

Compound 3, half-maximal inhibitory concentration: 16500 nM
Compound 3: the middle estimate sits 1.2-fold (0.07 log units) below what was measured; the measured number falls inside the stated range.
By their numbers in this assay, from the lowest: compounds 3, 2 and 1 (each within the scatter of the next).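

For the compounds shown here, the exchange of 4-methoxyphenyl for 4-chlorophenyl gives, in this assay, a 1.3-fold lower number from compound 1 to compound 3 (0.10 log units; within the scatter), and this is the first step that isolates a single place, on an aromatic carbon para to a large group. At this place, a methoxy group with its one hydrogen-bond acceptor and a chloro group with none leave compound 1 and compound 3 indistinguishable on this read-out, so the acceptor count of this substituent shows no measurable link to the cytotoxicity number in this single pair. No independent measurement is available that bears on this result, and the pair offers no explanation for it.

On these data alone, both substituents tested at this place are neutral and small, so it remains open whether an amine, a carboxylic acid or a longer alkoxy chain on the outer ring would give a step beyond the scatter in this assay. As far as these compounds go, it also remains open whether the same exchange of methoxy for chloro would read the same way on a different linking ring, as the evidence here rests on one pair built on the core of compound 1.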